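Adding a Second Methoxy Group: Expectation for Compound 4

The source may report more compounds than this note shows. Statements on the series, on what has been measured and on what is new or still open speak of the compounds shown alone.

Compound 1 `COc1ccccc1C1CC(c2cc(OC)c(OC)c(OC)c2)=NN1C(C)=O`: > 100000 nM
Compound 2 `COc1ccc(OC)c(C2CC(c3cc(OC)c(OC)c(OC)c3)=NN2C(C)=O)c1`: > 100000 nM
Compound 3 `COc1ccc(C2CC(c3cc(OC)c(OC)c(OC)c3)=NN2)cc1OC`: 44000 nM

In a functional assay on B16 cells (Mus musculus) for cytotoxicity, read by MTT assay, with a stated time of 72 h (on this read-out lower numbers stand for stronger inhibition and higher numbers for weaker inhibition), compound 1 gives only a limit of the assay, > 100000 nM. Compound 2 likewise gives only a limit, > 100000 nM. For the measured compounds named here, compound 3 gives 44000 nM, the one number among the three. The difference between the core of compound 1 and that of compound 3 is not broken down here.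

Compound 1 and compound 2 differ by methoxy in place of hydrogen on an aromatic carbon. The step between them, a step that the two limits leave unreadable from compound 1 to compound 2, cannot be read because both sit at the limit of > 100000 nM in this assay, at which 2 of the 3 values shown sit.

Compound 4 `COc1cc(C2=NNC(c3cc(OC)c(OC)c(OC)c3)C2)cc(OC)c1OC` has not yet been measured in this assay. It differs from compound 3 by methoxy in place of hydrogen on an aromatic carbon. This is the same kind of change as that from compound 1 to compound 2, though the surroundings differ: in the earlier pair the new methoxy sits meta to a large group and para to a methoxy group, whereas in compound 4 it sits ortho to a methoxy group, meta to a large group and meta to a methoxy group.

Compound 4 is expected to lie near 30000 nM, somewhere between 8000 nM and 150000 nM. Going by the values given here, the expected step for compound 4, a 1.5-fold lower number from compound 3 to compound 4 (0.17 log units; within the scatter), is an estimate only, as the one comparable measured step is unreadable, and it rests on compound 3 at 44000 nM.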

Compound 4, half-maximal inhibitory concentration: 56000 nM
Beside the measured number, compound 4's estimate is 1.9-fold (0.27 log units) below it; low and high end bracket the measured number.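

In this assay, methoxy in place of hydrogen on an aromatic carbon gives a 1.3-fold higher number from compound 3 to compound 4 (0.10 log units; within the scatter), so on this core the change makes no difference that can be told apart from repeat measurements. The same kind of change on the other core cannot be read, because compound 1 and compound 2 both give only a limit of the assay: the limit of > 100000 nM in this assay, at which 2 of the 4 values shown sit. The new pair therefore shows the outcome of the change on one core only; it does not show whether that outcome carries over from one core to the other, and the surroundings also differ, since the new methoxy in compound 4 sits ortho to a methoxy group, meta to a large group and meta to a methoxy group.

The compounds shown leave open whether anything other than methoxy at this place on the ring would move the number beyond the scatter, for instance an amine or a carboxylic acid. They also leave open whether a longer chain in place of the methoxy would do so, and whether any such change would give a readable step on the core of compound 1.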